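The source may report more compounds than this note shows. Statements on the series, on what has been measured and on what is new or still open speak of the compounds shown alone.

Working notes on the series. Compound 2, `CCC(=O)N1CC[C@H](Nc2ncnc3c2nc(-c2cnn(CC)c2C)n3C)C1`, is the starting point. In an ADME assay on isolated protein for inhibition of dual 3',5'-cyclic-AMP and -GMP phosphodiesterase 11A (Homo sapiens) (a higher number here means a weaker inhibitor, a lower number a stronger inhibitor), compound 2 gives > 20000 nM, which is a limit of the assay and not a number. Compound 1, `CCn1ncc(-c2nc3c(O[C@H]4CCN(C(=O)C5CCOCC5)C4)ncnc3n2C)c1C`, gives > 20000 nM in this assay, again a limit. Going by the values given here, both results therefore rest on (the limit of > 20000 nM in this assay, at which 2 of the 2 values shown sit), so no step between measured compounds can be read, and where compound 2 stands can only be said as: not below that limit.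

The next compound is compound 3, `CCn1ncc(-c2nc3c(N[C@H]4CCN(C(=O)C5CCOCC5)C4)ncnc3n2C)c1C`. Its change from compound 2 is oxan-4-yl in place of ethyl on a carbonyl carbon. Among the compounds with values here, no measured step covers such a change here. Given that compound 2 sits at a limit, the expected step from compound 2 to compound 3 in this assay, a step that the limit leaves unreadable from compound 2 to compound 3, is no more than the scatter, most likely with compound 3 again reported as a limit. Compound 3 is estimated at 30000 nM, with a range from 8000 nM to 120000 nM.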

Compound 3, half-maximal inhibitory concentration: > 20000 nM
Compound 3: no number, only a limit (the forecaster's own chance of this, stated with the estimate: 85%); the middle value lies beyond the limit too.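

Compound 3 gives > 20000 nM in this assay, again a limit of the assay, so no step from compound 2 to compound 3 can be read, and the same holds for compound 1: the limit of > 20000 nM in this assay, at which 3 of the 3 values shown sit.

The compounds shown leave open whether any change among them alters inhibition, since none gives a number.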